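Purine acetamide series: from compound 2 to compound 4

The source may hold more compounds than are shown below. What is called first, only, known or untested is meant among the compounds shown, and "the series" means these compounds.

Of the compounds shown here, three have been measured in a functional assay on the whole organism (Tail, strain ICR) with Mus musculus as the target, in the tail flick test, with a stated time of 120 min, at a dose of 25 umol/kg by the oral route; on this read-out higher numbers stand for a stronger effect at the one dose given and lower numbers for a weaker effect. Compound 1 `O=C(CN(c1nc(Cl)nc2[nH]cnc12)C1CC1)N[C@@H](CC(=O)OCc1ccccc1)C(=O)OCc1ccccc1` gives 12.1%. Compound 3 `O=C(CN(c1nc(Cl)nc2[nH]cnc12)C1CC1)N[C@@H](CO)C(=O)O` gives 39%. Compound 2 `NC(=O)CC[C@H](NC(=O)CN(c1ncnc2c1ncn2C1CCCCO1)C1CC1)C(=O)OCc1ccccc1` gives 22.3% in this assay, which places compound 2 second highest of the three numbers: compound 1 stands lower by a gap beyond the scatter, and compound 3 stands higher by a larger gap, also beyond the scatter.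

Compound 4 `C[C@@H](O)[C@H](NC(=O)CN(c1ncnc2c1ncn2C1CCCCO1)C1CC1)C(=O)OCc1ccccc1` has not yet been measured. It differs from compound 2 in one place: 1-hydroxyethyl in place of 2-carbamoylethyl on a saturated chain carbon bound to an amide-type nitrogen and a carbonyl carbon. Among the compounds with values here, no pair of measured compounds differs in exactly one place, so no measured step guides the size or direction of this change. The step from compound 2 to compound 4 in this assay is therefore expected to be small, most likely within the scatter, with no firm direction: a number 1.7 percentage points higher from compound 2 to compound 4 (within the scatter). For compound 4 the estimate in this assay is 24%, expected to fall between 10% and 42%.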

Compound 4, a percentage reported as activity, at one dose (the size of the read-out at that dose, not a potency): 10.9%
Estimate against measurement, compound 4: 13.1 percentage points above; the range from low to high includes it.
By their numbers in this assay, from the lowest: compounds 4 and 1 (each within the scatter of the next); then compound 2; then compound 3.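

In this assay, the position on a saturated chain carbon bound to an amide-type nitrogen and a carbonyl carbon now proves sensitive to the group it carries: 1-hydroxyethyl in place of 2-carbamoylethyl gives a number 11.4 percentage points lower from compound 2 to compound 4 (beyond the scatter). Within the data shown here, this is the first one-place comparison, and it shows that the effect of compound 2 at the one dose given is not retained with the change from 5 heavy atoms to 3, even though both groups have 1 hydrogen-bond donor and 1 hydrogen-bond acceptor. No measured evidence is available to explain this step.

A single step cannot separate the contribution of chain length from that of the carbamoyl group. The compounds shown also leave open what an amine or a plain methyl would give at this position.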